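This account rests on a few compounds, and the source may have more. Where it says the series, first, only, none or still open, it means among the compounds named here.

Compound 1 `CC(C)(C)COC(=O)N1CCC(Oc2ncnc3c2CCN3c2ccc(S(C)(=O)=O)cc2F)CC1`, compound 2 `CS(=O)(=O)c1ccc(N2CCc3c(OC4CCN(C(=O)OCCF)CC4)ncnc32)c(F)c1` and compound 3 `COCCOC(=O)N1CCC(Oc2ncnc3c2CCN3c2ccc(S(C)(=O)=O)cc2F)CC1` share one core and differ only in the group on the amine nitrogen in the ring. In a functional assay on CHO-K1 cells for agonist activity at Glucose-dependent insulinotropic receptor (Homo sapiens), read by a luciferase reporter, with a stated time of 5 h (on this read-out higher numbers stand for an effect only at larger amounts of compound and lower numbers for an effect already at smaller amounts), compound 1 gives 39.8 nM, compound 2 gives 501 nM and compound 3 gives 316 nM; compound 3 thus stands second highest of the three, near compound 2 and well away from compound 1. Compound 4 `CN(C)S(=O)(=O)N1CCC(Oc2ncnc3c2CCN3c2ccc(S(C)(=O)=O)cc2F)CC1` carries dimethylsulfamoyl in place of (2-methoxyethoxy)carbonyl on an amine nitrogen in a ring. Every measured change kept the carbonyl and altered only its chain: a 13-fold higher number from compound 1 to compound 2 (1.10 log units; beyond the scatter) and a 7.9-fold higher number from compound 1 to compound 3 (0.90 log units; beyond the scatter), whereas a 1.6-fold lower number from compound 2 to compound 3 (0.20 log units; within the scatter). Within the data shown here, no measured step removes the carbonyl itself, so the guidance is indirect; compounds 2 and 3 lie close together, and a further group of that kind is expected to land near them. Compound 4 is therefore expected at 400 nM (range 100 nM to 1600 nM), a step of a 1.3-fold higher number from compound 3 to compound 4 (0.10 log units; within the scatter) expected to stay within the scatter.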

Compound 4, half-maximal effective concentration: 398 nM
Beside the measured number, compound 4's estimate is 1.0-fold (0.00 log units) above it; the range from low to high includes it.
By their numbers in this assay, from the lowest: compound 1; then compounds 3, 4 and 2 (each within the scatter of the next).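

Among these compounds, the dimethylsulfamoyl group is the first change here that removes the carbonyl itself, and in this assay the result stays level with the two smaller carbonyl groups: a 1.3-fold higher number from compound 3 to compound 4 (0.10 log units; within the scatter) and a 1.3-fold lower number from compound 2 to compound 4 (0.10 log units; within the scatter). Losing the carbonyl therefore costs nothing measurable against those two, yet a 10-fold higher number from compound 1 to compound 4 (1.00 log units; beyond the scatter) shows that neopentyloxycarbonyl still stands apart from all three other groups. No measurement on hand explains these results. Still open, on these data alone, is whether the bulky neopentyl chain would bring the same gain on another link, as in a neopentylsulfonyl group or a urea carrying that chain.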